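Carrying one aryl change from one core to another

The source may hold more compounds than are shown below. What is called first, only, known or untested is meant among the compounds shown, and "the series" means these compounds.

Compound 1 `COc1ccc(/C=C/C(=O)C(=Cc2ccc(O)c(F)c2)C(=O)/C=C/c2ccc(OC)cc2OC)c(OC)c1` gives 1760 nM in a functional assay on HepG2 cells (Homo sapiens) for antiproliferative activity, read by sulforhodamine B assay, with a stated time of 48 h; a lower number here means a stronger inhibitor, a higher number a weaker inhibitor.
Compound 2 `COc1ccc(/C=C/C(=O)C(=Cc2cc(Br)c(O)c(OC)c2)C(=O)/C=C/c2ccc(OC)cc2OC)c(OC)c1` gives 1190 nM in this assay.
Compound 3 `COc1cc(OC)c(/C=C/C(=O)C(=Cc2ccc(O)c(F)c2)C(=O)/C=C/c2c(OC)cc(OC)cc2OC)c(OC)c1` gives 810 nM in this assay.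

Compound 2 differs from compound 1 in one place: 3-bromo-4-hydroxy-5-methoxyphenyl in place of 3-fluoro-4-hydroxyphenyl on a double-bonded chain carbon bound to a double-bonded chain carbon. That change produced a 1.5-fold lower number from compound 1 to compound 2 (0.17 log units; within the scatter), so the two values sit within the scatter of each other. Compound 3 rests on a different core; the difference between the two cores is not broken down here. Compared with compound 1 it shows a number that is lower by an amount beyond the scatter, while against compound 2 it lies within the scatter.

Compound 4 `COc1cc(OC)c(/C=C/C(=O)C(=Cc2cc(Br)c(O)c(OC)c2)C(=O)/C=C/c2c(OC)cc(OC)cc2OC)c(OC)c1` is the unmeasured partner of compound 3, and the change is the same as the one already seen: 3-bromo-4-hydroxy-5-methoxyphenyl in place of 3-fluoro-4-hydroxyphenyl on a double-bonded chain carbon bound to a double-bonded chain carbon. Because the same change gave a 1.5-fold lower number from compound 1 to compound 2 (0.17 log units; within the scatter) on the core of compound 1, compound 4 is expected to show a step of a 1.4-fold lower number from compound 3 to compound 4 (0.13 log units; within the scatter) in this assay, again within the scatter. On that basis compound 4 is estimated at 600 nM, with the likely range running from 300 nM to 1200 nM.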

Compound 4, half-maximal inhibitory concentration: 660 nM
Estimate against measurement, compound 4: 1.1-fold (0.04 log units) below, within the range that was stated.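

In this assay, putting 3-bromo-4-hydroxy-5-methoxyphenyl in place of 3-fluoro-4-hydroxyphenyl on the core of compound 3 gives a 1.2-fold lower number from compound 3 to compound 4 (0.09 log units; within the scatter), so this pair sits within the scatter of each other, as the pair on the core of compound 1 does. The change therefore reads the same on both cores: the same change on two cores in this assay, a 1.5-fold lower number (0.17 log units; within the scatter) from compound 1 to compound 2 and a 1.2-fold lower number (0.09 log units; within the scatter) from compound 3 to compound 4, 1.2-fold (0.08 log units) apart, within the scatter of two such steps

Within the data shown here, this shows only that the change leaves no readable step on either of these two cores, not that it has a real effect that carries over, since agreement between two steps this small cannot separate a shared effect from no effect at all.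

The compounds shown leave open how the bromine and the methoxy group of the entering aryl group each count, as they always arrive together and always replace the fluorine as a set. Also open, going by these compounds, is whether a phenyl group carrying an amine or a carboxylic acid at the same place would give a step that can be read on either core.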